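This account rests on a few compounds, and the source may have more. Where it says the series, first, only, none or still open, it means among the compounds named here.

Working notes on the series. Three compounds have numbers in an assay on HEK293 cells for inhibition of acid ceramidase (Homo sapiens), read by fluorescence, with stated times of 10 min and 3 h; a higher number here means a weaker inhibitor, a lower number a stronger inhibitor. Compound 1 `CC(C)CNC(=O)n1c(=O)oc2ccc(C3CCN(C)CC3)cc21` gives 295 nM in this assay. Compound 2 `O=C(NCCCCc1ccccc1)n1c(=O)oc2cc(C3CCOCC3)ccc21` gives 68 nM in this assay. Compound 3 `O=C(NCCCCc1ccccc1)n1c2c(oc1=O)CNCC2` gives 340 nM in this assay. Compound 2 stands at the lowest of the three numbers; the gap to compound 1 and the gap to compound 3 both lie beyond the usual scatter, so compound 2 is the strongest inhibitor measured so far.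

The next compound, compound 4 `O=C(NCCCCc1ccccc1)n1c(=O)oc2cc(C3CCCCC3)ccc21`, keeps the rest of compound 2 and changes one group: cyclohexyl in place of oxan-4-yl on an aromatic carbon. For the measured compounds named here, no pair of measured compounds differs in just this way, so the size of the step has to be judged without a direct precedent. The change keeps the ring size and the attachment point and swaps one ring atom. A step of this kind is expected to stay within the scatter, in either direction.

Compound 4 is therefore expected to come out near 60 nM in this assay, with a range from 20 nM to 200 nM. The expected step from compound 2 to compound 4 is a 1.1-fold lower number from compound 2 to compound 4 (0.05 log units; within the scatter).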

Compound 4, half-maximal inhibitory concentration: 89 nM
Compound 4: the middle estimate sits 1.5-fold (0.17 log units) below what was measured, within the range that was stated.
By their numbers in this assay, from the lowest: compounds 2 and 4 (each within the scatter of the next); then compounds 1 and 3 (each within the scatter of the next).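

Cyclohexyl in place of oxan-4-yl on this aromatic carbon gives a 1.3-fold higher number from compound 2 to compound 4 (0.12 log units; within the scatter) in this assay, the first step in the series that isolates a single change. In this pair, the ring oxygen and its hydrogen-bond acceptor can be lost without a step beyond the scatter, so this acceptor is not required to keep the number at this level. No measurement here bears on what lies behind the step.

The compounds shown leave open how a phenyl ring, a piperidin-4-yl ring or a carboxylic acid on this aromatic carbon would read in this assay. Also open, as far as these compounds go, is whether the same swap gives a step of this size with a shorter chain in place of the phenylbutyl chain.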